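A Methoxy Step Carried Onto a Larger Core

The source may report more compounds than this note shows. Statements on the series, on what has been measured and on what is new or still open speak of the compounds shown alone.

Three compounds have been measured in a functional assay on MCF7 cells (Homo sapiens) for cytotoxicity, read by MTT assay, with a stated time of 24 h; a lower number here means a stronger inhibitor, a higher number a weaker inhibitor:
- compound 1, `COc1cccc2cc(N=[N+]=[N-])c(=O)oc12`, gives 31500 nM
- compound 2, `NCCC(=O)N1Cc2ccccc2-c2nnn(-c3cc4ccccc4oc3=O)c2-c2ccccc21`, gives 12700 nM
- compound 3, `[N-]=[N+]=Nc1cc2ccccc2oc1=O`, gives 26700 nM

Compound 1 differs from compound 3 by a single change, (methoxy in place of hydrogen on an aromatic carbon), and that change made a 1.2-fold higher number from compound 3 to compound 1 (0.07 log units; within the scatter). Compound 2 stands lowest of the three measured values, and how its core differs from the core of compound 3 is not broken down here; its value is beyond the scatter from both others.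

Compound 4, `COc1cccc2cc(-n3nnc4c3-c3ccccc3N(C(=O)CCN)Cc3ccccc3-4)c(=O)oc12`, has not yet been measured. It differs from compound 2 by methoxy in place of hydrogen on an aromatic carbon, and the place of that change is described in the same words as for the step from compound 3 to compound 1, so it is the same change. Because that earlier step was a 1.2-fold higher number from compound 3 to compound 1 (0.07 log units; within the scatter), the methoxy is expected to move the number little here as well, and the step from compound 2 to compound 4 is estimated at a 1.2-fold higher number from compound 2 to compound 4 (0.07 log units; within the scatter) in this assay. Compound 4 is therefore expected to give about 15000 nM, likely between 7000 nM and 32000 nM.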

Compound 4, half-maximal inhibitory concentration: 21900 nM
Compound 4: middle estimate off by 1.5-fold (0.16 log units), on the low side, within the range that was stated.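

In this assay, methoxy in place of hydrogen on an aromatic carbon gave a 1.7-fold higher number from compound 2 to compound 4 (0.24 log units; within the scatter), so on this larger core the change again left the number within the scatter. Set beside the earlier step, the result shows that the change carried over from one core to the other without a detectable difference: the same change on two cores in this assay, a 1.2-fold higher number (0.07 log units; within the scatter) from compound 3 to compound 1 and a 1.7-fold higher number (0.24 log units; within the scatter) from compound 2 to compound 4, 1.5-fold (0.16 log units) apart, within the scatter of two such steps This rests on only two cores and on steps that both lie within the scatter, so it does not show that the gap between them is real, that the methoxy has any effect of its own in this assay, or that the same would hold on a third core.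

The compounds shown leave open whether a different group at this place, such as hydroxyl, ethoxy or fluorine, would move the number beyond the scatter. Also open, from the compounds shown here alone, is what a carboxylic acid in place of the amine of compound 2 would do.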